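A few compounds are considered here, and "the series" means these few. Any claim that something is new, unique, unknown or untested is made for them only; others in the source may bear on it.

Three compounds have so far been run through an ADME assay for pharmacokinetics, read by LC-MS, in phosphate buffer, with a stated time of 120 min, at pH 7.4, tested at 1 uM, in the presence of a further agent that is not named here; on this read-out higher numbers stand for a longer-lived compound and lower numbers for a shorter-lived compound. Compound 1 `O=C(/C=C/CC(=O)Nc1ccccc1)Nc1ccccc1` joins two anilide groups through a short unsaturated chain. In this assay compound 1 gives > 8.53 h, which is a limit of the assay rather than a number. Compound 3 `CN1CCN(C/C=C/C(=O)Nc2ccccc2)CC1` gives > 8.53 h in this assay, again a limit. Compound 2 `C=C(CO)C(=O)Nc1ccccc1` is the starting point of the step followed here; in this assay compound 2 gives > 8.53 h, likewise a limit. The three results are thus summarised by the limit of > 8.53 h in this assay, at which 3 of the 3 values shown sit, so nothing in the numbers separates compound 2 from compound 1 or compound 3, and no measured step between any pair of these compounds exists.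

Compound 4 `C=C(F)C(=O)Nc1ccccc1` has not yet been measured. The change from compound 2 is fluoro in place of hydroxymethyl on a double-bonded chain carbon bound to a carbonyl carbon. Among the compounds with values here, with no measured step of this kind among the compounds at hand, the expectation rests on the change alone and is uncertain. A shorter half-life is expected in this assay, with the expected step being an at least 2.8-fold lower number from compound 2 to compound 4 (0.45 log units; beyond the scatter). For compound 4 the estimated half-life in this assay is 3 h, within a range from 0.5 h to 8.53 h, and it remains possible that the assay again reports only a limit.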

Compound 4, half-life: > 8.53 h
Compound 4: no number, only a limit; the forecaster's own chance of this, stated with the estimate: 35%; middle value at least 2.8-fold (0.45 log units) away from the limit.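

In this assay compound 4 gives only a limit, as compound 2 does, so no step between compound 2 and compound 4 can be read: the limit of > 8.53 h in this assay, at which 4 of the 4 values shown sit.

The compounds shown leave open whether fluoro in place of hydroxymethyl on a double-bonded chain carbon bound to a carbonyl carbon changes the half-life at all.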